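The compounds below may be only part of what the source reports. "The series", "measured", "known", "first", "only" and "open" are said of these compounds alone.

Three analogues share one core and differ only in the group carried on a saturated chain carbon bound to a sulfur. In a functional assay on SW-620 cells (Homo sapiens) for cytotoxicity, read by MTT assay, with stated times of 4 h and 72 h, tested at 5 uM (on this read-out lower numbers stand for stronger inhibition and higher numbers for weaker inhibition), compound 1 `Cc1ccc(CSc2nc3nc(C)cc(Nc4ccc(C(=O)/C=C/c5ccc6ccccc6c5)cc4)n3n2)cc1` gives 880 nM, compound 2 `Cc1cc(Nc2ccc(C(=O)/C=C/c3ccc4ccccc4c3)cc2)n2nc(SCc3ccccc3C(F)(F)F)nc2n1` gives 1240 nM, and compound 3 `Cc1cc(Nc2ccc(C(=O)/C=C/c3ccc4ccccc4c3)cc2)n2nc(SCc3ccccc3[N+](=O)[O-])nc2n1` gives 960 nM. Compound 3 thus holds the second highest of the three numbers, yet the steps of a 1.1-fold higher number from compound 1 to compound 3 (0.04 log units; within the scatter) and a 1.3-fold lower number from compound 2 to compound 3 (0.11 log units; within the scatter) both stay within the scatter, as does a 1.4-fold higher number from compound 1 to compound 2 (0.15 log units; within the scatter). Compound 4 `COc1ccc(CSc2nc3nc(C)cc(Nc4ccc(C(=O)/C=C/c5ccc6ccccc6c5)cc4)n3n2)cc1` carries 4-methoxyphenyl in place of 2-nitrophenyl on a saturated chain carbon bound to a sulfur. Each measured exchange on that saturated chain carbon bound to a sulfur stayed within the scatter, so no step beyond the scatter is expected here either. The estimate for compound 4 is therefore 950 nM, with a range from 500 nM to 1900 nM. That estimate means a step of a 1.0-fold lower number from compound 3 to compound 4 (0.00 log units; within the scatter), expected to lie within the scatter.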

Compound 4, half-maximal inhibitory concentration: 250 nM
Estimate against measurement, compound 4: 3.8-fold (0.58 log units) above; the measured number lies below the stated range.
By their numbers in this assay, from the lowest: compound 4; then compounds 1, 3 and 2 (each within the scatter of the next).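

Within the data shown here, on a saturated chain carbon bound to a sulfur, exchanges are no longer silent in this assay: 4-methoxyphenyl brings a 3.8-fold lower number from compound 3 to compound 4 (0.58 log units; beyond the scatter) and a 5.0-fold lower number from compound 2 to compound 4 (0.70 log units; beyond the scatter) and a 3.5-fold lower number from compound 1 to compound 4 (0.55 log units; beyond the scatter) as the first steps here beyond the scatter. The last of these is only methoxy in place of methyl on an aromatic carbon, so one small exchange on that ring separates compound 4 from the other three. Nothing given here bears on why this happens. Still open, going by these compounds, is whether this step is specific to methoxy, which ethoxy or hydroxy in its place would test. Cyclohexyl in place of the whole 4-methoxyphenyl would show whether the aromatic ring is needed at all.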